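Swapping cyano for trifluoromethyl in a mouse potency series

The compounds below may be only part of what the source reports. "The series", "measured", "known", "first", "only" and "open" are said of these compounds alone.

Compound 1 `Cc1cc(CCC(=O)O)ccc1-c1noc(-c2ccc(OC(C)C)c(C#N)c2)n1`: 0.1 mg/kg
Compound 2 `Cc1cc([C@@H]2C[C@H]2C(=O)O)ccc1-c1noc(-c2ccc(OC(C)C)c(C(F)(F)F)c2)n1`: 0.2 mg/kg
Compound 3 `Cc1nc(CCC(=O)O)ccc1-c1noc(-c2ccc(OC(C)C)c(C#N)c2)n1`: 0.2 mg/kg

These three compounds were tested in a functional assay on the whole organism with Mus musculus as the target; a lower number here means that less compound is needed, a higher number that more compound is needed for the effect. Compound 1 gives 0.1 mg/kg, and the values of compound 2 and compound 3 both lie within the usual scatter of that number. On these data, the three cannot be told apart, so compound 1 stands level with the others rather than ahead of them.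

The next compound to be tested is compound 4 `Cc1cc(CCC(=O)O)ccc1-c1noc(-c2ccc(OC(C)C)c(C(F)(F)F)c2)n1`. It keeps the core of compound 1 and changes one group: trifluoromethyl takes the place of cyano on an aromatic carbon, ortho to an isopropoxy group and meta to a large group (trifluoromethyl in place of cyano on an aromatic carbon).

Among the measured compounds shown here, no two measured compounds differ in only one place, so this swap has no direct precedent here. The nearest hint is compound 2, which also carries trifluoromethyl, although it differs from compound 1 elsewhere too. Compound 2 still gives 0.2 mg/kg, so no step beyond the scatter is expected in this assay. The estimate is a step of a 1.5-fold higher number from compound 1 to compound 4 (0.18 log units; within the scatter), which is expected to stay within the scatter. For compound 4 the expected value is 0.15 mg/kg, with an estimated range from 0.05 mg/kg to 0.4 mg/kg.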

Compound 4, dose for half-maximal effect: 0.3 mg/kg
Estimate against measurement, compound 4: 2.0-fold (0.30 log units) below; low and high end bracket the measured number.
By their numbers in this assay, from the lowest: compounds 1, 2, 3 and 4 (each within the scatter of the next, the first and the last beyond it).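

In this assay, among the compounds shown here, this is the first direct reading of the swap at this position, ortho to an isopropoxy group: with the rest of the molecule unchanged, trifluoromethyl in place of cyano gives a 3.0-fold higher number from compound 1 to compound 4 (0.48 log units; beyond the scatter), a modest step, with more compound needed for the effect. The other new comparison keeps trifluoromethyl and changes only the acid-bearing group, with 2-carboxyethyl in place of 2-carboxycyclopropyl, and gives a 1.5-fold higher number from compound 2 to compound 4 (0.18 log units; within the scatter), so these two compounds cannot be told apart in this assay. Nothing measured here explains why the swap from cyano to trifluoromethyl produces its step.

The compounds shown leave open whether the same swap gives a step of similar size when 2-carboxycyclopropyl stands in place of 2-carboxyethyl. They also leave open how other small groups on this aromatic carbon, such as a chlorine atom, a methyl group or a primary amide, would compare with cyano and trifluoromethyl.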